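The source may report more compounds than this note shows. Statements on the series, on what has been measured and on what is new or still open speak of the compounds shown alone.

Working notes on the series. Two amides of the shared core have been measured in an assay for inhibition of Polyunsaturated fatty acid 5-lipoxygenase (Homo sapiens), read by spectrophotometry, tested at 20 uM; on this read-out lower numbers stand for less inhibition and higher numbers for more inhibition at the one concentration tested (going by the name of the read-out). Compound 1, `O=C(/C=C/C=C/c1ccc(Cl)cc1)N1CCCCC1`, gives 14.5% in this assay, the lowest of the two numbers seen. Compound 2, `O=C(/C=C/C=C/c1cc(O)c(O)c(O)c1)N1CCCCC1`, gives 82.5%, a number well beyond the scatter above that of compound 1; the two differ in more than one place, so nothing more is drawn from that pair.

The next compound is compound 3, `O=C(/C=C/C=C/c1ccccc1)N1CCCCC1`, unmeasured so far. It differs from compound 1 only at the aromatic carbon: hydrogen in place of chloro on an aromatic carbon. Going by the values given here, no measured pair in the set shows what such a change does in this assay. With compound 1 sitting at 14.5%, the step of a number 4.5 percentage points lower from compound 1 to compound 3 (within the scatter) is expected to stay within the scatter, if anything slightly downward. Compound 3 is therefore estimated at 10%, in the range 0% to 30%.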

Compound 3, a percentage reported as inhibition, at one concentration (the size of the read-out at that concentration, not a potency): 36.3%
For compound 3 the middle estimate is 26.3 percentage points below the measured one; the whole stated range lies below it.
By their numbers in this assay, from the lowest: compound 1; then compound 3; then compound 2.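

Read in this assay, hydrogen in place of chloro on an aromatic carbon para to a large group gives a number 21.8 percentage points higher from compound 1 to compound 3 (beyond the scatter) and provides the first step in the series that can be read at a single place. This position is therefore not indifferent to the change, since removing the chloro of compound 1 and altering nothing else moves the number beyond the scatter. Nothing on hand explains this step.

Open, on these data alone, is whether the step is particular to chloro or would also appear with another group on this carbon, such as fluoro, methoxy or a single hydroxyl. Also open, as far as these compounds go, is whether a step of this size would recur with a different amide group on the same chain, such as a morpholine amide.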